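The compounds below may be only part of what the source reports. "The series", "measured", "known", "first", "only" and "open" are said of these compounds alone.

Measured in an ADME assay on microsomes from liver (Mus musculus) for metabolic stability, using NADPH, with a stated time of 60 min, in the presence of a further agent that is not named here; on this read-out lower numbers stand for slow clearance and higher numbers for fast clearance:

Compound 1 `O=C(O)COc1ccc([C@H]2CC[C@]3(CC2)OOC2(O3)C3CC4CC(C3)CC2C4)cc1Cl` gives 8 mL.min-1.g-1.
Compound 2 `O=C(O)CN1CCC(Oc2ccc([C@H]3CC[C@]4(CC3)OOC3(O4)C4CC5CC(C4)CC3C5)cc2)CC1` gives < 7 mL.min-1.g-1, which is a limit of the assay and not a number.
Compound 3 `O=C(O)CCCCOc1ccc([C@H]2CC[C@]3(CC2)OOC2(O3)C3CC4CC(C3)CC2C4)cc1` gives 13 mL.min-1.g-1.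

Compound 3, at 13 mL.min-1.g-1, lies within the scatter of compound 1, at 8 mL.min-1.g-1. For the measured compounds named here, these are the only two numbers available, since the result for compound 2 is a limit.

Compound 4 `O=C(O)CCCOc1ccc([C@H]2CC[C@]3(CC2)OOC2(O3)C3CC4CC(C3)CC2C4)cc1` differs from compound 3 in one place: carboxy in place of carboxymethyl on a saturated chain carbon, three bonds along the chain from an oxygen on an aromatic ring. This puts carboxy in place of carboxymethyl on a saturated chain carbon, three bonds along the chain from an oxygen on an aromatic ring, so that 4-carboxybutyl becomes 3-carboxypropyl.

Going by the values given here, only one measured step bears on this, and only loosely: an at least 1.8-fold higher number from compound 2 to compound 3 (0.26 log units; that floor lies within the scatter). Among the compounds with values here, that step exchanges 1-(carboxymethyl)piperidin-4-yl for 4-carboxybutyl, and no measured pair differs by chain length alone. No step beyond the scatter is therefore expected in this assay.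

The expected step, a 1.3-fold lower number from compound 3 to compound 4 (0.11 log units; within the scatter), is an estimate that stays within the scatter.

The estimated value for compound 4 is 10 mL.min-1.g-1, with an expected range from 6 mL.min-1.g-1 to 17 mL.min-1.g-1.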

Compound 4, intrinsic clearance in microsomes: 8 mL.min-1.g-1
Compound 4: middle estimate off by 1.3-fold (0.10 log units), on the high side, and the stated range covers the measured number.
By their numbers in this assay, from the lowest: compounds 1, 4 and 3 (each within the scatter of the next). At a limit, below all of these: compound 2.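

In this assay, for the compounds shown here, carboxy in place of carboxymethyl on a saturated chain carbon, three bonds along the chain from an oxygen on an aromatic ring, gives a 1.6-fold lower number from compound 3 to compound 4 (0.21 log units; within the scatter); this is the first measured pair to differ by chain length alone, and the change from 4-carboxybutyl to 3-carboxypropyl stays within the scatter. Putting 3-carboxypropyl in place of 1-(carboxymethyl)piperidin-4-yl on an oxygen on an aromatic ring gives an at least 1.1-fold higher number from compound 2 to compound 4 (0.05 log units; that floor lies within the scatter), so this floor does not separate the two groups any more than the earlier one for the 4-carboxybutyl chain did. Compound 2 gives a limit of the assay and not a number: the limit of < 7 mL.min-1.g-1 in this assay, at which 1 of the 4 values shown sits.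

As far as these compounds go, it remains open whether a shorter chain such as 2-carboxyethyl or carboxymethyl, or a chain longer than 4-carboxybutyl, on that oxygen would give a step beyond the scatter in this assay. From the compounds shown here alone, it is also open how an amide or an amine in place of the carboxylic acid would read there.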